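Second fluoro on the aniline ring of compound 1

The source may report more compounds than this note shows. Statements on the series, on what has been measured and on what is new or still open speak of the compounds shown alone.

Measured so far:
compound 1 `Cn1cc(-c2ccc(NC(=O)c3cn(CC4CCOCC4)cc(-c4ccc(F)cc4)c3=O)c(F)c2)c2c(N)ncnc21` — 210 nM
compound 2 `Cn1cc(-c2ccc(NC(=O)c3cn(CC4CCOCC4)cc(-c4ccccc4)c3=O)cc2)c2c(N)ncnc21` — 318 nM
compound 3 `Cn1cc(-c2ccc(NC(=O)c3cn(CC4CCOCC4)cc(-c4ccc(C(F)(F)F)cc4)c3=O)cc2)c2c(N)ncnc21` — 826 nM

In a functional assay on MKN-45 cells (Homo sapiens) for antiproliferative activity, with a stated time of 72 h (a higher number here means a weaker inhibitor, a lower number a stronger inhibitor), compound 1 gives the lowest number of the three. Its gap to compound 2 lies within the scatter; its gap to compound 3 lies beyond it. Among the compounds with values here, the one measured step, a 2.6-fold higher number from compound 2 to compound 3 (0.41 log units; beyond the scatter), sits on a different aryl group and does not bear on the change considered here.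

Compound 4 `Cn1cc(-c2cc(F)c(NC(=O)c3cn(CC4CCOCC4)cc(-c4ccc(F)cc4)c3=O)cc2F)c2c(N)ncnc21` differs from compound 1 by fluoro in place of hydrogen on an aromatic carbon. No measured step in this series tests such a change, so no direction can be read from the numbers shown; a step of a 1.1-fold higher number from compound 1 to compound 4 (0.04 log units; within the scatter) is expected, within the scatter, in this assay. Compound 4 is therefore estimated at 230 nM, with a range of 90 nM to 600 nM.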

Compound 4, half-maximal inhibitory concentration: 53.7 nM
Compound 4: middle estimate off by 4.3-fold (0.63 log units), on the high side; measured number below the stated range.
By their numbers in this assay, from the lowest: compound 4; then compounds 1 and 2 (each within the scatter of the next); then compound 3.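

In this assay, fluoro in place of hydrogen on an aromatic carbon, ortho to a large group and para to a fluoro group, gives a 3.9-fold lower number from compound 1 to compound 4 (0.59 log units; beyond the scatter) and so lies beyond the scatter. Within the data shown here, this is the first measured single change on this ring and shows that this carbon can shift the antiproliferative read-out. Nothing measured here explains the step.

On these data alone, whether chloro, methyl or methoxy at this carbon gives a comparable step remains open. Also open, as far as these compounds go, is whether the gain carries over to compound 2 or compound 3, which carry no fluoro on this ring.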